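This account rests on a few compounds, and the source may have more. Where it says the series, first, only, none or still open, it means among the compounds named here.

The three measured compounds, each tested in a functional assay on K562 cells (Homo sapiens) for inhibition, read by MTT assay, with a stated time of 72 h; on this read-out lower numbers stand for stronger inhibition and higher numbers for weaker inhibition:

Compound 1 `Cc1ccc(-c2cn(-c3ccc(CN4CCN(C)CC4)cc3)nn2)cc1Nc1nccc(-c2cccnc2)n1` gives 4700 nM.
Compound 2 `Cc1ccc(-c2cn(-c3ccc(CN4CCN(C)CC4)c(C(F)(F)F)c3)nn2)cc1Nc1nccc(-c2cccnc2)n1` gives 30 nM.
Compound 3 `Cc1ccc(-c2cn(-c3ccc(CN4CCCCC4)cc3)nn2)cc1Nc1nccc(-c2cccnc2)n1` gives 3290 nM.

Among these three numbers compound 3 stands second highest. Its nearest neighbour is compound 1, and the gap between them, a 1.4-fold lower number from compound 1 to compound 3 (0.15 log units; within the scatter), is small enough to count as no real difference. Within the data shown here, compound 2 stands far away with a much lower number, reached by a 160-fold lower number from compound 1 to compound 2 (2.19 log units; beyond the scatter), which is the only large step in this set.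

Compound 4 `Cc1ccc(-c2cn(-c3ccc(CN4CCCC4)cc3)nn2)cc1Nc1nccc(-c2cccnc2)n1` differs from compound 3 by a single change: pyrrolidin-1-yl in place of piperidin-1-yl on a saturated chain carbon bound to an aromatic carbon. One saturated ring attached through a nitrogen at this position is exchanged for a slightly smaller one. The step that bears on this is the earlier swap at the same place, a 1.4-fold lower number from compound 1 to compound 3 (0.15 log units; within the scatter), which stayed within the scatter. The large step to compound 2 concerns a different position and does not inform this change. For compound 4 a step of a 1.1-fold higher number from compound 3 to compound 4 (0.03 log units; within the scatter) is therefore expected, with no clear direction beyond the scatter. The estimated value for compound 4 is 3500 nM, in the range 1400 nM to 9000 nM.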

Compound 4, half-maximal inhibitory concentration: 3890 nM
For compound 4 the middle estimate is 1.1-fold (0.05 log units) below the measured one; measured number inside the range.
By their numbers in this assay, from the lowest: compound 2; then compounds 3, 4 and 1 (each within the scatter of the next).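

In this assay, going from the piperidin-1-yl ring to the smaller pyrrolidin-1-yl ring on the saturated chain carbon gives a 1.2-fold higher number from compound 3 to compound 4 (0.07 log units; within the scatter), so this change in ring size has no real effect on the number. Putting pyrrolidin-1-yl in place of 4-methylpiperazin-1-yl gives a 1.2-fold lower number from compound 1 to compound 4 (0.08 log units; within the scatter), so three different rings at this place now give numbers that cannot be told apart. No other measurement is available that bears on this result.

On these data alone, it remains open whether a morpholin-4-yl ring or an open-chain dimethylamino group at this place would also leave the number unchanged. Also open, as far as these compounds go, is whether the trifluoromethyl gain, a 160-fold lower number from compound 1 to compound 2 (2.19 log units; beyond the scatter), would carry over to the compounds with piperidin-1-yl or pyrrolidin-1-yl.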